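Swapping 4-methylphenyl for 3-chloropropyl

The compounds below may be only part of what the source reports. "The series", "measured", "known", "first", "only" and "open" are said of these compounds alone.

Measured so far in a functional assay on HCT-116 cells (Homo sapiens) for antiproliferative activity, read by MTT assay, with a stated time of 72 h (a higher number here means a weaker inhibitor, a lower number a stronger inhibitor), are these compounds:
Compound 1 `CCCCc1cn(C[C@H](O)[C@H]2OC(=O)C(OCc3ccccc3)=C2OCc2ccccc2)nn1` gives 10400 nM
Compound 2 `Cc1ccc(-c2cn(C[C@H](O)[C@H]3OC(=O)C(OCc4ccccc4)=C3OCc3ccccc3)nn2)cc1` gives > 100000 nM as a limit

The value of compound 2 is > 100000 nM and is a limit of the assay, not a number. Compound 3 `O=C1O[C@H]([C@@H](O)Cn2cc(CCCCl)nn2)C(OCc2ccccc2)=C1OCc1ccccc1` carries 3-chloropropyl in place of 4-methylphenyl on an aromatic carbon, counted as 3-chloropropyl in place of 4-methylphenyl on an aromatic carbon here. Among the measured compounds shown here, one measured step bears on this, namely an at least 9.6-fold higher number from compound 1 to compound 2 (0.98 log units; beyond the scatter) when 4-methylphenyl replaces butyl, and it lies beyond the scatter. With no ring in the new group, much of that step is expected to reverse in this assay towards a lower number, giving an expected at least 8.3-fold lower number from compound 2 to compound 3 (0.92 log units; beyond the scatter) overall. Compound 3 is estimated at 12000 nM within 3500 nM to 45000 nM in this reading.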

Compound 3, half-maximal inhibitory concentration: 36100 nM
Compound 3: middle estimate off by 3.0-fold (0.48 log units), on the low side, and the stated range covers the measured number.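

In this assay, an open chain at this position gives a measurable number where 4-methylphenyl did not, with an at least 2.7-fold lower number from compound 2 to compound 3 (0.44 log units; beyond the scatter). The chain is not enough by itself, since chloro in place of methyl on a saturated chain carbon also counts, with a 3.5-fold higher number from compound 1 to compound 3 (0.54 log units; beyond the scatter). The first step is only a bound, as compound 2 stands at a limit and not at a number: the limit of > 100000 nM in this assay, at which 1 of the 3 values shown sits.

Still open, going by these compounds, is whether an amine or a longer chain here would give a lower number than butyl does. On these data alone, it is also open whether an unsubstituted phenyl would fare like 4-methylphenyl.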